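This account rests on a few compounds, and the source may have more. Where it says the series, first, only, none or still open, it means among the compounds named here.

Measured so far, with an ADME assay on a cell-free system (plasma, Homo sapiens) for protein binding (on this read-out lower numbers stand for a smaller free fraction and higher numbers for a larger free fraction), as the read-out:
compound 1 `CC(=O)N1CCC(C(=O)N2CC[C@](c3ccc(C(F)(C(F)(F)F)C(F)(F)F)cc3)(S(=O)(=O)c3ccc(F)cc3)C2)CC1` gives "not determined" (no result reported)
compound 2 `O=C(O)C1CCN(C(=O)N2CC[C@](c3ccc(C(F)(C(F)(F)F)C(F)(F)F)cc3)(S(=O)(=O)c3ccc(F)cc3)C2)CC1` gives "not determined" (no result reported)
compound 3 `Cc1ccc(S(=O)(=O)[C@@]2(c3ccc(C(F)(C(F)(F)F)C(F)(F)F)cc3)CCN(C(=O)[C@H]3CC[C@H](C(=O)O)CC3)C2)cc1` gives 0.013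

For the measured compounds named here, compound 3 holds the only number, so it cannot be ranked against the others. Neither compound 1 nor compound 2 has a reported result. Compound 4 `Cc1cc(S(=O)(=O)[C@@]2(c3ccc(C(F)(C(F)(F)F)C(F)(F)F)cc3)CCN(C(=O)[C@H]3CC[C@H](C(=O)O)CC3)C2)ccc1F` has 4-fluoro-3-methylphenyl in place of 4-methylphenyl on a sulfonyl sulfur and is otherwise the same as compound 3. Going by the values given here, no measured step shows what such a change does here. The expected 1.2-fold lower number from compound 3 to compound 4 (0.07 log units; within the scatter) in this assay therefore lies within the usual scatter, with no firm direction. The estimate for compound 4 is 0.011 in an expected range from 0.005 to 0.022 as its upper end.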

Compound 4, unbound fraction: 0.017
Compound 4: the middle estimate sits 1.5-fold (0.19 log units) below what was measured; the range from low to high includes it.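

In this assay, for the compounds shown here, the change from 4-methylphenyl to 4-fluoro-3-methylphenyl on a sulfonyl sulfur gives a 1.3-fold higher number from compound 3 to compound 4 (0.12 log units; within the scatter) and is the first step that can be read. At this position, the added fluorine and the shifted methyl leave the unbound fraction within the scatter. No available evidence bears on this result. The compounds shown leave open whether a pyridine ring or an amine-bearing phenyl on the sulfonyl sulfur would produce a step beyond the scatter.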